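The source may report more compounds than this note shows. Statements on the series, on what has been measured and on what is new or still open speak of the compounds shown alone.

Compounds measured so far in a functional assay on 1321-N1 cells for agonist activity at P2Y purinoceptor 6 (Homo sapiens), read by scintillation counting and inositol phosphate accumulation; on this read-out higher numbers stand for an effect only at larger amounts of compound and lower numbers for an effect already at smaller amounts: compound 1 `O=C(O)CCCO/N=c1/ccn([C@@H]2O[C@H](COP(=O)(O)OP(=O)(O)OP(=O)(O)O)[C@@H](O)[C@H]2O)c(=O)[nH]1` gives 697 nM; compound 2 `O=c1[nH]/c(=N\OCCOc2ccccc2)ccn1[C@@H]1O[C@H](COP(=O)(O)OP(=O)(O)OP(=O)(O)O)[C@@H](O)[C@H]1O` gives 1780 nM; compound 3 `O=c1[nH]/c(=N\OCCCc2ccc(Br)cc2)ccn1[C@@H]1O[C@H](COP(=O)(O)OP(=O)(O)OP(=O)(O)O)[C@@H](O)[C@H]1O` gives 225 nM.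

Compound 3 stands lowest of the three numbers in this assay. Its nearest neighbour is compound 1, reached by a 3.1-fold lower number from compound 1 to compound 3 (0.49 log units; beyond the scatter); its furthest is compound 2, reached by a 7.9-fold lower number from compound 2 to compound 3 (0.90 log units; beyond the scatter). The remaining pair gives a 2.6-fold higher number from compound 1 to compound 2 (0.41 log units; beyond the scatter).

Compound 4 `O=c1[nH]/c(=N\OCCCc2ccsc2)ccn1[C@@H]1O[C@H](COP(=O)(O)OP(=O)(O)OP(=O)(O)O)[C@@H](O)[C@H]1O` differs from compound 3 by thiophen-3-yl in place of 4-bromophenyl on a saturated chain carbon, three bonds along the chain from an oxygen. Going by the values given here, the steps that bear on this change are the two that alter the group at the same end of the chain: a 3.1-fold lower number from compound 1 to compound 3 (0.49 log units; beyond the scatter) and a 7.9-fold lower number from compound 2 to compound 3 (0.90 log units; beyond the scatter). Both are modest in size and both end at compound 3, so the group at this position has so far moved the numbers in this assay by modest amounts only, with the 4-bromophenyl giving the lowest number seen. With a smaller ring entering, the expectation is a modest rise in the number, a 2.2-fold higher number from compound 3 to compound 4 (0.35 log units; beyond the scatter), not beyond the range spanned by compound 1 and compound 2. The estimate for compound 4 in this assay is 500 nM, expected to fall between 200 nM and 1300 nM.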

Compound 4, half-maximal effective concentration: 164 nM
Compound 4: the middle estimate sits 3.0-fold (0.48 log units) above what was measured; measured number outside the range, below it.
By their numbers in this assay, from the lowest: compounds 4 and 3 (each within the scatter of the next); then compound 1; then compound 2.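

Thiophen-3-yl in place of 4-bromophenyl gives a 1.4-fold lower number from compound 3 to compound 4 (0.14 log units; within the scatter) in this assay, so at this chain end neither the bromine nor the six-membered ring is required to keep the number at the level of compound 3. Going by these compounds alone, the remaining steps, a 4.3-fold lower number from compound 1 to compound 4 (0.63 log units; beyond the scatter) and an 11-fold lower number from compound 2 to compound 4 (1.04 log units; beyond the scatter), set compound 4 apart from both the carboxy-ended chain and the phenoxy-ended chain, and the second of these is the first large step; an aromatic ring at the chain end is therefore not enough on its own, as the phenoxy group of compound 2 also carries one yet has the highest number of the four. No measured property or other supporting data accompanies these results to account for the differences.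

Going by these compounds, it remains open how much of the gap to compound 2 belongs to the oxygen in its chain and how much to its shorter chain. A plain 3-phenylpropyl group, a thiophen-2-yl ring, a primary amine at the chain end or a longer chain carrying thiophen-3-yl would each test a separate part of this.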